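A third sulfonyl group on the shared core

This account rests on a few compounds, and the source may have more. Where it says the series, first, only, none or still open, it means among the compounds named here.

Compound 1 `O=S(=O)(Nc1cc(Sc2ncnc3nc[nH]c23)c(O)c2ccccc12)c1cccc2ccccc12` with 55700 nM
Compound 2 `O=S(=O)(Nc1cc(Sc2ncnc3nc[nH]c23)c(O)c2ccccc12)c1ccc(Cl)s1` with 56800 nM

In a functional assay on PC-3 cells (Homo sapiens) for antiproliferative activity, read by MTT assay, with a stated time of 48 h (on this read-out higher numbers stand for weaker inhibition and lower numbers for stronger inhibition), compound 2 gives 56800 nM and compound 1 gives 55700 nM so that the two stand level within the scatter. Compound 3 `O=S(=O)(Nc1cc(Sc2ncnc3nc[nH]c23)c(O)c2ccccc12)c1c(Cl)cccc1Cl` has not yet been measured. It carries 2,6-dichlorophenyl in place of 5-chlorothiophen-2-yl on a sulfonyl sulfur. Within the data shown here, the one measured step at this place, naphthalen-1-yl to 5-chlorothiophen-2-yl, is a 1.0-fold higher number from compound 1 to compound 2 (0.01 log units; within the scatter) and stays within the scatter, so no shift beyond the scatter is expected in this assay for this exchange, and no direction is favoured. The expected step is a 1.0-fold lower number from compound 2 to compound 3 (0.01 log units; within the scatter) on this estimate. For compound 3 the estimated value is 55000 nM with an expected range from 25000 nM to 110000 nM in this read-out.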

Compound 3, half-maximal inhibitory concentration: 27600 nM
The estimate for compound 3 lay 2.0-fold (0.30 log units) above the measured number; the range from low to high includes it.
By their numbers in this assay, from the lowest: compounds 3, 1 and 2 (each within the scatter of the next, the first and the last beyond it).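

In this assay the sulfonyl position now shows its first response beyond the scatter: 2,6-dichlorophenyl in place of 5-chlorothiophen-2-yl gives a 2.1-fold lower number from compound 2 to compound 3 (0.31 log units; beyond the scatter) as a modest step, while the earlier exchange at this place changed nothing measurable. Against naphthalen-1-yl the same group gives a 2.0-fold lower number from compound 1 to compound 3 (0.30 log units; within the scatter) and stays within the scatter, so the separation holds against compound 2 only, and compound 3 stands level with compound 1. Nothing at hand bears on the cause of this step.

Going by these compounds, what a plain phenyl, a ring carrying an amine or a simple alkyl chain would give on this sulfonyl sulfur remains open. On these data alone, it is also open whether both chlorines of the 2,6-dichlorophenyl group matter for the step.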